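The source may report more compounds than this note shows. Statements on the series, on what has been measured and on what is new or still open speak of the compounds shown alone.

Working notes on the series.

The series is tested in a functional assay for inhibition, with Homo sapiens as the target; a lower number here means a stronger inhibitor, a higher number a weaker inhibitor. Compound 1, `CCc1ncn2c(S)nncc12`, carries ethyl and sulfanyl on the shared core. In this assay compound 1 gives > 48000 nM, which is a limit of the assay and not a number. Compound 2, `Cc1ncn2c(N(C)C)nncc12`, carries methyl and dimethylamino on the same core. In this assay compound 2 gives > 48000 nM, again a limit of the assay and not a number. Within the data shown here, compound 2 therefore stands at the limit of > 48000 nM in this assay, at which 2 of the 2 values shown sit, with no measured inhibitory strength to place it against compound 1; the two values show only that neither compound reaches the range of the assay, and no step between them can be stated.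

Compound 3, `Cc1ncn2c(S)nncc12`, is not yet measured. It differs from compound 2 by sulfanyl in place of dimethylamino on an aromatic carbon. Compound 1 already carries sulfanyl at that place and sits at the limit, so no step beyond the scatter is expected in this assay. The expected step is a step that the limit leaves unreadable from compound 2 to compound 3, in no clear direction. Compound 3 is estimated at 90000 nM in this assay, within 25000 nM to 400000 nM, most likely returned as a limit rather than a number.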

Compound 3, half-maximal inhibitory concentration: > 48000 nM
Compound 3 ended at the assay's limit (the forecaster's own chance of this, stated with the estimate: 85%); the middle value lies beyond the limit too.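

In this assay compound 3 gives > 48000 nM as a limit of the assay and not a number. No step from compound 1 or compound 2 to compound 3 can be read, and all three compounds stand at one limit: the limit of > 48000 nM in this assay, at which 3 of the 3 values shown sit.

Still open, from the compounds shown here alone, is whether any compound on the shared core reaches a measurable inhibitory strength in this assay and how sulfanyl, dimethylamino, methyl and ethyl would then compare.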